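The source may hold more compounds than are shown below. What is called first, only, known or untested is meant among the compounds shown, and "the series" means these compounds.

In a functional assay (aorta) for inhibition, with Rattus norvegicus as the target, with a stated time of 8 days (a higher number here means a weaker inhibitor, a lower number a stronger inhibitor), compound 1 (`Cc1nsc(-c2ccc(N3CCN(c4cccc(C(F)(F)F)c4)CC3)nc2)n1`) gives 5 nM and compound 2 (`FC(F)(F)c1cccc(N2CCN(c3ccc(-c4ncns4)nn3)CC2)c1`) gives 70 nM as the higher of the two numbers, which makes compound 2 the weaker inhibitor of the pair by a gap beyond the usual scatter. Compound 3 (`Nc1nsc(-c2ccc(N3CCN(c4cccc(C(F)(F)F)c4)CC3)nn2)n1`) alters compound 2 in one place: amino in place of hydrogen on an aromatic carbon is the counted difference, with amino in place of hydrogen on an aromatic carbon, so that 1,2,4-thiadiazol-5-yl becomes 3-amino-1,2,4-thiadiazol-5-yl. For the measured compounds named here, no measured step in a single place exists to guide this, so only a modest move to a lower number is expected, since compound 1 at 5 nM is the one lower value seen so far. The expected step of a 2.3-fold lower number from compound 2 to compound 3 (0.37 log units; beyond the scatter) is small, only just past the usual scatter. In this assay the estimated value for compound 3 is 30 nM within 7 nM to 130 nM as the likely span.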

Compound 3, half-maximal inhibitory concentration: 20 nM
For compound 3 the middle estimate is 1.5-fold (0.18 log units) above the measured one; measured number inside the range.
By their numbers in this assay, from the lowest: compound 1; then compound 3; then compound 2.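

In this assay, the aromatic carbon between two ring nitrogen atoms, two ring bonds from the ring sulfur, accepts a substituent without a loss of inhibition: placing amino there instead of hydrogen gives a 3.5-fold lower number from compound 2 to compound 3 (0.54 log units; beyond the scatter). For the compounds shown here, the lower number marks a stronger inhibitor, and this is the first change in a single place, so the effect of this one position can now be read on its own. Nothing measured here explains why the amino group has this effect.

On these data alone, it remains open whether the gain is specific to amino or would also appear with a hydroxyl, a dimethylamino or an acetamide group at the same carbon. Also open, as far as these compounds go, is whether swapping in amino would give a similar step on the core of compound 1.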